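The source may report more compounds than this note shows. Statements on the series, on what has been measured and on what is new or still open speak of the compounds shown alone.

Measured compounds:
compound 1 `Cn1nc(-c2ccccc2)c2cc(C(=N)Nc3ccccc3)ncc21` gives 17400 nM in a functional assay on HT-1080 cells (Homo sapiens) for cytotoxicity, read by MTT assay, with a stated time of 72 h; a higher number here means a weaker inhibitor, a lower number a stronger inhibitor;
compound 2 `CN1CCN(c2ccc(NC(=N)c3cc4cnn(C)c4cn3)cc2)CC1` gives 24000 nM in this assay;
compound 3 `CN1CCN(c2ccc(NC(=N)c3cc4c(-c5ccccc5)n[nH]c4cn3)cc2)CC1` gives 11400 nM in this assay.

Compound 3 carries the lowest number of the three, yet its separation from compound 1 lies within the scatter, while the separation from compound 2 lies beyond it. Compound 2 and compound 3 differ in more than one place, so their two values are set down side by side without reading a step into them.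

Compound 4 `CN1CCN(c2ccc(NC(=N)c3cc4c(-c5ccccc5)nn(C)c4cn3)cc2)CC1` has not yet been measured in this assay. It departs from compound 3 by methyl in place of hydrogen on an aromatic nitrogen of a five-membered aromatic ring with 2 nitrogen, part of a fused system of two rings, two ring bonds from the ring atom that bears a phenyl group. Within the data shown here, no single-change step between measured compounds exists here to calibrate this change. The expectation for compound 4 is therefore a modest shift, if any, not clearly beyond the scatter, and leaning toward a somewhat higher number. The step expected from compound 3 to compound 4 in this assay is a 1.3-fold higher number from compound 3 to compound 4 (0.12 log units; within the scatter). Compound 4 is thus estimated at 15000 nM, within a range from 5000 nM to 45000 nM.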

Compound 4, half-maximal inhibitory concentration: 1400 nM
Compound 4: the middle estimate sits 11-fold (1.03 log units) above what was measured, outside the stated range (below it).
By their numbers in this assay, from the lowest: compound 4; then compounds 3, 1 and 2 (each within the scatter of the next, the first and the last beyond it).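

In this assay the aromatic nitrogen proves sensitive to substitution: methyl in place of hydrogen there gives an 8.1-fold lower number from compound 3 to compound 4 (0.91 log units; beyond the scatter) and so the hydrogen on this nitrogen is not required for the lower number. With this methyl present, phenyl in place of hydrogen on an aromatic carbon gives a 17-fold lower number from compound 2 to compound 4 (1.23 log units; beyond the scatter) and 4-methylpiperazin-1-yl in place of hydrogen on an aromatic carbon gives a 12-fold lower number from compound 1 to compound 4 (1.09 log units; beyond the scatter) and so neither group can be removed from compound 4 without a clear rise in the number. Nothing at hand accounts for the effect of the methyl.

Open, going by these compounds, is whether ethyl or a longer chain ending in an amine on this nitrogen would keep the lower number. Also open, on these data alone, is whether a carboxylic acid on the phenyl would be tolerated.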